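A second methoxy on compound 3

The compounds below may be only part of what the source reports. "The series", "measured", "known", "first", "only" and "open" are said of these compounds alone.

Of the compounds shown here, three sharing one core have been measured in a physicochemical assay for lipophilicity, measured as octanol-water partition; a lower number here means a more polar compound, a higher number a more lipophilic compound: compound 1 (`O=C(NNc1ccnc2cc(Cl)ccc12)c1ccccc1/N=C/c1ccc(Cl)cc1`) gives 5.62, compound 2 (`O=C(NNc1ccnc2cc(Cl)ccc12)c1ccccc1/N=C/c1ccc(Cl)cc1Cl`) gives 6.22, and compound 3 (`COc1ccc(/C=N/c2ccccc2C(=O)NNc2ccnc3cc(Cl)ccc23)cc1`) gives 5, the lowest of the three. Compound 4 (`COc1ccc(/C=N/c2ccccc2C(=O)NNc2ccnc3cc(Cl)ccc23)cc1OC`) has methoxy in place of hydrogen on an aromatic carbon, ortho to a methoxy group and meta to a large group: methoxy in place of hydrogen on an aromatic carbon. For the measured compounds named here, no measured step makes exactly this change, but two come close. Chloro in place of hydrogen gave a modest step, a number 0.60 log units higher from compound 1 to compound 2 (beyond the scatter), and methoxy in place of chloro gave another, a number 0.62 log units lower from compound 1 to compound 3 (beyond the scatter). Taken together these nearly cancel, so the expected step, no change at the digits printed from compound 3 to compound 4 (within the scatter), stays within the scatter. Compound 4 is estimated at 5, with an expected range from 4.6 to 5.35.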

Compound 4, partition coefficient: 4.97
Beside the measured number, compound 4's estimate is 0.03 log units above it; the range from low to high includes it.
By their numbers in this assay, from the lowest: compounds 4 and 3 (each within the scatter of the next); then compound 1; then compound 2.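

Methoxy in place of hydrogen, ortho to a methoxy group, gives a number 0.03 log units lower from compound 3 to compound 4 (within the scatter), so this assay cannot tell these two compounds apart. The 3,4-dimethoxyphenyl group still stands well clear of both chlorinated groups, with a number 1.25 log units lower from compound 2 to compound 4 (beyond the scatter) and a number 0.65 log units lower from compound 1 to compound 4 (beyond the scatter). No measurement here offers an explanation for the result. As far as these compounds go, whether methoxy elsewhere on this ring would give the same result remains open. So does what an amine or a carboxylic acid would do at this position.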